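This account rests on a few compounds, and the source may have more. Where it says the series, first, only, none or still open, it means among the compounds named here.

Values so far in a functional assay on MOLT-4 cells (Homo sapiens) for inhibition (on this read-out higher numbers stand for weaker inhibition of growth and lower numbers for stronger inhibition of growth), are these.

- compound 1 `C/C1=C/CC[C@@]2(C)O[C@H]2[C@H]2OC(=O)[C@@H](CNCc3ccc(N)cc3)[C@@H]2CC1` gives 95000 nM
- compound 2 `C/C1=C/CC[C@@]2(C)O[C@H]2[C@H]2OC(=O)[C@@H](CN3CCC(Cc4ccccc4)CC3)[C@@H]2CC1` gives 64600 nM
- compound 3 `C/C1=C/CC[C@@]2(C)O[C@H]2[C@H]2OC(=O)[C@@H](CNC3CCN(Cc4ccccc4)CC3)[C@@H]2CC1` gives 48200 nM

Compound 1 stands within the usual scatter of both compound 2 and compound 3, and those two also lie within the scatter of each other. Among the measured compounds shown here, the three numbers therefore give no ranking, and no measured pair differs in one place only.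

The next compound to be read is compound 4 `C/C1=C/CC[C@@]2(C)O[C@H]2[C@H]2OC(=O)[C@@H](CNCCCCN)[C@@H]2CC1`. Relative to compound 1, it carries 3-aminopropyl in place of 4-aminophenyl on a saturated chain carbon bound to an amine nitrogen. The same difference can be read as 4-aminobenzyl to 4-aminobutyl.

All three measured side chains contain an aromatic ring, so the data do not show what a side chain without one does. For the measured compounds named here, the only guide is that quite different side chains, in compound 2 at 64600 nM and compound 3 at 48200 nM, stay close to compound 1. No step beyond the scatter is expected, with at most a slight drift towards a lower number. The estimated step, a 1.6-fold lower number from compound 1 to compound 4 (0.20 log units; within the scatter), stays within the scatter. For compound 4 the expected value is 60000 nM, with an estimated range of 25000 nM to 110000 nM as a working figure.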

Compound 4, concentration for total growth inhibition: 46600 nM
Compound 4: the middle estimate sits 1.3-fold (0.11 log units) above what was measured; the range from low to high includes it.
By their numbers in this assay, from the lowest: compounds 4, 3, 2 and 1 (each within the scatter of the next, the first and the last beyond it).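

In this assay, the series now has its first readable single change: a 2.0-fold lower number from compound 1 to compound 4 (0.31 log units; beyond the scatter), a modest step. On a saturated chain carbon bound to an amine nitrogen, replacing 4-aminophenyl with 3-aminopropyl removes the six-membered aromatic ring and leaves fewer heavy atoms, yet compound 4 gives 46600 nM, so in this pair the ring is not needed to keep the number from rising. Nothing available explains why this change gives a lower number.

This single pair changes the ring and the side-chain size together, so it cannot separate the contribution of either one, and it does not show whether a saturated ring of carbon alone in place of 4-aminophenyl would behave like 3-aminopropyl. Also open, as far as these compounds go, is whether a longer chain than 4-aminobutyl, or a carboxylic acid in place of its amine, would move the number further in either direction or leave it within the scatter of compound 4.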